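Adding Fluorine to the Outer Ring of Sigma-1 Ligands

The source may report more compounds than this note shows. Statements on the series, on what has been measured and on what is new or still open speak of the compounds shown alone.

Measured compounds and their values:
compound 1 `Fc1ccc(C(SCCNC2CCN(Cc3ccccc3)CC2)c2ccc(F)cc2)cc1` gives 3.81 nM
compound 2 `Fc1ccc(CN2CCC(NCCSC(c3ccc(F)cc3)c3ccc(F)cc3)CC2)cc1` gives 13.3 nM
compound 3 `O=C(c1ccccc1)N1CCC(NCC[S+]([O-])C(c2ccc(F)cc2)c2ccc(F)cc2)CC1` gives 585 nM

All three were tested in an assay on membranes from Cortex for displacement of a labelled ligand from Sigma non-opioid intracellular receptor 1 (Cavia porcellus), read by scintillation counting, with a stated time of 120 min; a higher number here means a weaker inhibitor, a lower number a stronger inhibitor. Compound 1 and compound 2 share one core and differ only by fluoro in place of hydrogen on an aromatic carbon; this change produced a 3.5-fold higher number from compound 1 to compound 2 (0.54 log units; beyond the scatter). Compound 3 is built on a different core, and the difference between the two cores is not broken down here; in this assay compound 3 gives the highest number of the three, and its gaps to compound 1 and compound 2 lie beyond the usual scatter.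

Compound 4 `O=C(c1ccc(F)cc1)N1CCC(NCC[S+]([O-])C(c2ccc(F)cc2)c2ccc(F)cc2)CC1` has not yet been measured. It differs from compound 3 by fluoro in place of hydrogen on an aromatic carbon, the same change seen between compound 1 and compound 2, at a place described in the same words, though on the other core. Because a 3.5-fold higher number from compound 1 to compound 2 (0.54 log units; beyond the scatter), compound 4 is expected to show a step of similar direction and size, a 3.1-fold higher number from compound 3 to compound 4 (0.49 log units; beyond the scatter). Compound 4 is therefore estimated at 1800 nM, within a range from 700 nM to 4500 nM.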

Compound 4, inhibition constant: 1440 nM
Estimate against measurement, compound 4: 1.3-fold (0.10 log units) above; the measured number falls inside the stated range.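

In this assay, placing a fluoro on the outer benzene ring makes the inhibitor weaker on the core of compound 3, giving a 2.5-fold higher number from compound 3 to compound 4 (0.39 log units; beyond the scatter). Set beside the earlier step, the change carried from one core to the other in the same direction, and the two sizes cannot be told apart: the same change on two cores in this assay, a 3.5-fold higher number (0.54 log units; beyond the scatter) from compound 1 to compound 2 and a 2.5-fold higher number (0.39 log units; beyond the scatter) from compound 3 to compound 4, 1.4-fold (0.15 log units) apart, within the scatter of two such steps This shows that the penalty for this fluoro held on these two cores in this one assay, but two pairs do not show that it will hold on every core in the series, and they do not explain why the number rises.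

The compounds shown leave open whether the step is specific to fluoro or whether another group at the same place, such as chloro, methyl or methoxy, would give a step of a different size or direction. As far as these compounds go, it also remains open whether the fluoro step would keep its size on a core carrying a longer chain.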